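From azepan-1-yl to pyrrolidin-1-yl on a shared core

The compounds below may be only part of what the source reports. "The series", "measured", "known", "first", "only" and "open" are said of these compounds alone.

Measured so far in a functional assay on MCF7 cells (Homo sapiens) for inhibition, read by MTT assay, with stated times of 18 h and 4 h; a lower number here means a stronger inhibitor, a higher number a weaker inhibitor:
- compound 1 `CCCCCCCCOP(=O)(O)OCCSC(=S)N1CCCC1`: 53000 nM
- compound 2 `CCCCCCCCCCOP(=O)(O)OCCSC(=S)N1CCCC1`: 70000 nM
- compound 3 `CCCCCCOP(=O)(O)OCCSC(=S)N1CCCCCC1`: 55000 nM

Compound 3 stands at 55000 nM, within the usual scatter of both compound 1 and compound 2, so the three values cannot be ranked. The next compound is compound 4 `CCCCCCOP(=O)(O)OCCSC(=S)N1CCCC1`, which has pyrrolidin-1-yl in place of azepan-1-yl on a thiocarbonyl carbon.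

For the measured compounds named here, no measured step makes this exchange directly. Going by the values given here, the only measured step, a 1.3-fold higher number from compound 1 to compound 2 (0.12 log units; within the scatter), is a change in the chain, with ethyl in place of hydrogen, and it stays within the scatter. It bears on the question only indirectly. Pyrrolidin-1-yl is already present in compound 1 at 53000 nM and in compound 2 at 70000 nM, and both values sit close to that of compound 3.

In this assay no shift beyond the scatter is therefore expected, and the expected step is a 1.1-fold lower number from compound 3 to compound 4 (0.02 log units; within the scatter). For compound 4 the estimated value is 52000 nM, with an expected range from 28000 nM to 95000 nM.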

Compound 4, half-maximal inhibitory concentration: 100000 nM
Estimate against measurement, compound 4: 1.9-fold (0.28 log units) below; the measured number lies above the stated range.
By their numbers in this assay, from the lowest: compounds 1, 3, 2 and 4 (each within the scatter of the next).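

In this assay, for the compounds shown here, this is the first direct reading of the exchange on a thiocarbonyl carbon, with pyrrolidin-1-yl entering and azepan-1-yl leaving, and it stays within the scatter (a 1.8-fold higher number from compound 3 to compound 4 (0.26 log units; within the scatter)). The two new chain steps also stay within the scatter (a 1.4-fold higher number from compound 2 to compound 4 (0.15 log units; within the scatter); a 1.9-fold higher number from compound 1 to compound 4 (0.28 log units; within the scatter)), so neither the ring exchange nor these chain changes separates the compounds in this assay. No independent measurement is available to explain the values or link them to any property of these groups.

Still open, from the compounds shown here alone, is whether a different amine on the thiocarbonyl carbon, such as piperidin-1-yl or morpholin-4-yl, would give a step beyond the scatter. The same question applies to a longer chain, such as dodecyl, on the shared core.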